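Methoxy-to-Methyl Swap at the Edge of Detection

The compounds below may be only part of what the source reports. "The series", "measured", "known", "first", "only" and "open" are said of these compounds alone.

Of the compounds shown here, three built on one shared core have been tested in a functional assay on PC-3 cells (Homo sapiens) for cytotoxicity, read by MTT assay, with a stated time of 72 h; a higher number here means a weaker inhibitor, a lower number a stronger inhibitor. Compound 1 `COc1ccc(-c2ccc(C(=O)Nc3ccc(Oc4ccnc5[nH]ccc45)cc3)nc2)cc1` gives > 10000 nM, which is a limit of the assay rather than a number. Compound 2 `O=C(Nc1ccc(Oc2ccnc3[nH]ccc23)cc1)c1ccc(-c2ccc(F)cc2F)cn1` likewise gives > 10000 nM, again a limit. The step that the two limits leave unreadable from compound 1 to compound 2 therefore cannot be read. Compound 3 `COc1ccc(-c2ccnc(C(=O)Nc3ccc(Oc4ccnc5[nH]ccc45)cc3)c2)cc1` is the only one of the three with an actual number: in this assay compound 3 gives 9620 nM. That number stands just short of the limit of > 10000 nM in this assay, at which 2 of the 3 values shown sit.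

Compound 4 `Cc1cccc(-c2ccnc(C(=O)Nc3ccc(Oc4ccnc5[nH]ccc45)cc3)c2)c1` differs from compound 3 in one place: 3-methylphenyl in place of 4-methoxyphenyl on an aromatic carbon. Within the data shown here, no measured step concerns this kind of change; the only measured step runs between two limits and shows nothing about its size, so there is no guide from the data to a direction. Compound 3 already sits close to the limit, and a modest shift either way would leave compound 4 in the same region. The step of a 1.2-fold higher number from compound 3 to compound 4 (0.10 log units; within the scatter) is expected to stay within the usual scatter. Compound 4 is therefore expected to give 12000 nM, with a range from 4000 nM to 40000 nM, and a fair chance that the assay reports only a limit for it.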

Compound 4, half-maximal inhibitory concentration: 5470 nM
Beside the measured number, compound 4's estimate is 2.2-fold (0.34 log units) above it; measured number inside the range.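

Among these compounds, at this position, opposite the ring nitrogen, a second compound now gives an actual number in this assay and not a limit, so a step can be read here for the first time. The result is a 1.8-fold lower number from compound 3 to compound 4 (0.25 log units; within the scatter): the change removes 4-methoxyphenyl, with its oxygen and its 1 hydrogen-bond acceptor, and brings in 3-methylphenyl, with 0 hydrogen-bond acceptors, yet the read-out cannot tell the two compounds apart. Two things change at once, the group itself and where it stands on its own ring, and this one pair cannot separate them, though it does show that this particular swap leaves no readable mark on the result.

Still open, from the compounds shown here alone, is whether any group at this position can move the number clear of the scatter, since both actual values stay in the same region as the assay's limit: the limit of > 10000 nM in this assay, at which 2 of the 4 values shown sit A group such as an amine or a carboxylic acid would test this on very different atoms, while 4-methylphenyl would show what the methyl does at the place the methoxy held.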